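The source may report more compounds than this note shows. Statements on the series, on what has been measured and on what is new or still open speak of the compounds shown alone.

Compound 1 `C=CCNc1cccnc1/C=N/N=C(/N)S`: > 10000 nM
Compound 2 `C=CCNc1ccc(/C=N/N=C(/N)S)nc1`: 4400 nM
Compound 3 `N/C(S)=N/N=C/c1ncc(N)cc1N`: 1100 nM

These values come from a functional assay on L1210 cells (Mus musculus) for inhibition; on this read-out lower numbers stand for stronger inhibition and higher numbers for weaker inhibition. The entry for compound 1 is a limit of the assay and not a number. Of the two true numbers, compound 2 holds the higher at 4400 nM, while compound 3 lies lower at 1100 nM, a gap beyond the usual scatter.

Compound 4 `NCc1ccc(/C=N/N=C(/N)S)nc1` is not yet measured. It carries aminomethyl in place of the allylamino of compound 2 on an aromatic carbon: aminomethyl in place of allylamino on an aromatic carbon. Compound 3, at 1100 nM, shows a lower number without allylamino, so a small move toward lower numbers in this assay is expected, possibly within the scatter. The expected change is a step of a 1.5-fold lower number from compound 2 to compound 4 (0.17 log units; within the scatter). For compound 4 the estimated value is 3000 nM, with an expected range of 1000 nM to 9000 nM.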

Compound 4, half-maximal inhibitory concentration: 2100 nM
The estimate for compound 4 lay 1.4-fold (0.15 log units) above the measured number, and the stated range covers the measured number.
By their numbers in this assay, from the lowest: compounds 3 and 4 (each within the scatter of the next); then compound 2. At a limit, above all of these: compound 1.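

In this assay, this aromatic carbon, two atoms from the ring nitrogen, responds to a change of side chain: aminomethyl in place of allylamino gives a 2.1-fold lower number from compound 2 to compound 4 (0.32 log units; beyond the scatter), a modest step. Allylamino is therefore not needed here for inhibition, and the smaller group does not weaken it. The compounds shown give no cause for this step.

From the compounds shown here alone, it remains open whether the chain's size or its double bond matters, which propylamino at this carbon could separate. A carboxylic acid there would test whether an amine is needed at all.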